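This account rests on a few compounds, and the source may have more. Where it says the series, first, only, none or still open, it means among the compounds named here.

Among the measured compounds shown here, compound 3 `O=C(CCCl)Nc1ccc(S(=O)(=O)Oc2ccccc2I)cc1` stands second highest of the three numbers measured so far in a functional assay on MCF7 cells (Homo sapiens) for antiproliferative activity, read by sulforhodamine B assay, with a stated time of 48 h (a higher number here means a weaker inhibitor, a lower number a stronger inhibitor), where compound 3 gives 8900 nM. Compound 2 `CC(C)(C)C(=O)Nc1ccc(S(=O)(=O)Oc2ccccc2I)cc1` gives 6600 nM, and the step of a 1.3-fold higher number from compound 2 to compound 3 (0.13 log units; within the scatter) stays within the scatter. Compound 1 `CC(=O)Nc1ccc(S(=O)(=O)Oc2ccccc2I)cc1` gives 27000 nM, and the step of a 3.0-fold lower number from compound 1 to compound 3 (0.48 log units; beyond the scatter) lies beyond the scatter, as does a 4.1-fold lower number from compound 1 to compound 2 (0.61 log units; beyond the scatter). Compound 4 `O=C(CCCCl)Nc1ccc(S(=O)(=O)Oc2ccccc2I)cc1` differs from compound 3 by chloromethyl in place of chloro on a saturated chain carbon, two bonds along the chain from a carbonyl carbon. For the measured compounds named here, two measured steps bear on this: a 3.0-fold lower number from compound 1 to compound 3 (0.48 log units; beyond the scatter), which added the same kind of chain, and a 1.3-fold higher number from compound 2 to compound 3 (0.13 log units; within the scatter), where a chain and a branched group gave numbers within the scatter of each other. Compound 4 is therefore expected to show only a small step, a 1.3-fold lower number from compound 3 to compound 4 (0.10 log units; within the scatter). For compound 4 the estimate is 7000 nM, with a range from 3000 nM to 16000 nM.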

Compound 4, half-maximal inhibitory concentration: 6300 nM
The estimate for compound 4 lay 1.1-fold (0.05 log units) above the measured number, and the stated range covers the measured number.
By their numbers in this assay, from the lowest: compounds 4, 2 and 3 (each within the scatter of the next); then compound 1.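

In this assay, going from 2-chloroethyl to 3-chloropropyl on the carbonyl gives a 1.4-fold lower number from compound 3 to compound 4 (0.15 log units; within the scatter) and so makes no clear difference at this position. The other steps agree: a 1.0-fold lower number from compound 2 to compound 4 (0.02 log units; within the scatter) leaves the chain and tert-butyl indistinguishable, and a 4.3-fold lower number from compound 1 to compound 4 (0.63 log units; beyond the scatter) shows that the clear separation from the acetyl compound persists with the added carbon. No available evidence explains these numbers. As far as these compounds go, whether a longer chain would keep this level remains open, as does whether an amine or a hydroxyl could take the place of the chloro at the chain end.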